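Compound 4 and the limit of the cytotoxicity assay

The compounds below may be only part of what the source reports. "The series", "measured", "known", "first", "only" and "open" are said of these compounds alone.

Measured so far in an ADME assay on HEK293 cells (Homo sapiens) for cytotoxicity, read by resazurin assay, with a stated time of 48 h (a higher number here means that more compound is tolerated, a lower number that less compound is tolerated), for three compounds:
Compound 1 `O=S(=O)(Nc1ccc(-c2nc3ccccc3o2)cc1)c1ccccc1Cl` gives > 100000 nM as a limit
Compound 2 `O=S(=O)(Nc1ccc(-c2nc3ccccc3o2)cc1)c1cccc(O)c1` gives > 100000 nM as a limit
Compound 3 `COc1ccc(Cl)cc1S(=O)(=O)Nc1ccc2oc(-c3ccccc3)nc2c1` gives 74000 nM as a number

Compound 2 stands at > 100000 nM and this is a limit of the assay, not a number. The readings offer little finer than the limit of > 100000 nM in this assay, at which 2 of the 3 values shown sit, as a guide. Compound 3 alone gives a number, with 74000 nM as its reading.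

Compound 4 `O=S(=O)(Nc1ccc(-c2nc3ccccc3o2)cc1)c1ccc(O)cc1` differs from compound 2 as 4-hydroxyphenyl in place of 3-hydroxyphenyl on a sulfonyl sulfur shows, with 4-hydroxyphenyl in place of 3-hydroxyphenyl on a sulfonyl sulfur. Within the data shown here, the one measured step at that place is a step that the two limits leave unreadable from compound 1 to compound 2 and it gives no size to carry over. No step beyond the scatter is therefore expected in this assay in either direction, and a further limit would be no surprise. The expected step is a number no higher from compound 2 to compound 4 (the limit leaves the size open) as an estimate. For compound 4 the estimated value is 100000 nM with an expected range from 50000 nM to 200000 nM in this assay.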

Compound 4, half-maximal cytotoxic concentration: > 100000 nM
Compound 4: only a limit was reported; the forecaster's own chance of this, stated with the estimate: 75%; the middle value sits exactly at the limit.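

No new step can be read among compound 1, compound 2 and compound 4 in this assay, because all three sit at the same limit: the limit of > 100000 nM in this assay, at which 3 of the 4 values shown sit.

The compounds shown leave open how far compound 1, compound 2 and compound 4 actually differ from one another in this assay.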